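Swapping halogens on the aniline ring of compound 3

The source may hold more compounds than are shown below. What is called first, only, known or untested is meant among the compounds shown, and "the series" means these compounds.

In a functional assay on NCI-H460 cells (Homo sapiens) for inhibition, read by sulforhodamine B assay, with a stated time of 48 h (on this read-out lower numbers stand for stronger inhibition of growth and higher numbers for weaker inhibition of growth), compound 3 (`CN1CCN(CCCOc2cccc3nc(Nc4ccc(F)c(F)c4)ccc23)CC1`) gives 2370 nM and lies within the scatter of compound 1 (`CN1CCN(CCCOc2cccc3nc(Nc4ccc(Cl)c(F)c4)ccc23)CC1`) with its 1910 nM on the same scale. Compound 2 (`CC(C)c1ccc(Nc2ccc3c(OCCCN4CCN(C)CC4)cccc3n2)cc1`) gives the higher 5440 nM here. Compound 4 (`CN1CCN(CCCOc2cccc3nc(Nc4cccc(Cl)c4)ccc23)CC1`) has 3-chlorophenyl in place of 3,4-difluorophenyl on a nitrogen on an aromatic ring. The nearest measured change, fluoro in place of chloro on an aromatic carbon, gave a 1.2-fold higher number from compound 1 to compound 3 (0.09 log units; within the scatter) and stayed within the scatter. Larger steps came with 4-isopropylphenyl: a 2.8-fold higher number from compound 1 to compound 2 (0.45 log units; beyond the scatter) and a 2.3-fold lower number from compound 2 to compound 3 (0.36 log units; beyond the scatter) on the way back. Compound 4 keeps a halogen on its phenyl. With a 1.2-fold higher number from compound 1 to compound 3 (0.09 log units; within the scatter) as the guide, no step beyond the scatter is expected, only an estimated 1.1-fold lower number from compound 3 to compound 4 (0.03 log units; within the scatter) in all. Compound 4 is therefore estimated at 2200 nM (expected range 1200 nM to 4000 nM).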

Compound 4, concentration for 50% growth inhibition: 1870 nM
Compound 4: the middle estimate sits 1.2-fold (0.07 log units) above what was measured; low and high end bracket the measured number.
By their numbers in this assay, from the lowest: compounds 4, 1 and 3 (each within the scatter of the next); then compound 2.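

In this assay, the 3-chlorophenyl group on this nitrogen reads no differently from the two rings carrying a fluorine, with a 1.3-fold lower number from compound 3 to compound 4 (0.10 log units; within the scatter) and a 1.0-fold lower number from compound 1 to compound 4 (0.01 log units; within the scatter) both printed as within the scatter. Across compounds 1, 3 and 4, then, changing which halogens the phenyl carries moves little, while 4-isopropylphenyl stands apart, with a 2.9-fold lower number from compound 2 to compound 4 (0.46 log units; beyond the scatter) and so beyond the scatter. Nothing measured here speaks to the reason for this.

Still open, from the compounds shown here alone, is whether a plain phenyl would read like these halogenated rings. An amine or a carboxylic acid on this phenyl is also untested among the compounds shown.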